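A few compounds are considered here, and "the series" means these few. Any claim that something is new, unique, unknown or untested is made for them only; others in the source may bear on it.

In a functional assay on MCF7 cells (Homo sapiens) for inhibition, read by CCK-8 assay, with a stated time of 48 h (a higher number here means a weaker inhibitor of growth, a lower number a stronger inhibitor of growth), compound 1 `Cc1ccccc1Nc1nc(Nc2ccccc2)ncc1Cl` gives > 100000 nM, which is a limit. Compound 2 `Cc1ccccc1Nc1nc(Nc2ccc(N3CCCCC3)cc2)ncc1Cl` gives > 100000 nM, also a limit. Compound 2 therefore has no number, only (the limit of > 100000 nM in this assay, at which 2 of the 2 values shown sit). Compound 3 `Cc1ccccc1Nc1nc(Nc2ccc(N3CCCN(C)CC3)cc2)ncc1Cl` carries 4-methyl-1,4-diazepan-1-yl in place of piperidin-1-yl on an aromatic carbon. Among the measured compounds shown here, the one measured step, a step that the two limits leave unreadable from compound 1 to compound 2, has no readable size, so it offers only weak support for expecting a small move towards stronger growth inhibition in this assay. The expected change is an at least 1.6-fold lower number from compound 2 to compound 3 (0.22 log units; that floor lies within the scatter), an estimate. For compound 3 the estimated value is 60000 nM, within an expected range of 10000 nM to 100000 nM.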

Compound 3, concentration for 50% growth inhibition: 4290 nM
Estimate against measurement, compound 3: 14-fold (1.15 log units) above; the whole stated range lies above it.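

In this assay this aromatic carbon responds to the group it carries: 4-methyl-1,4-diazepan-1-yl gives an at least 23-fold lower number from compound 2 to compound 3 (1.36 log units; beyond the scatter) and, set against hydrogen, an at least 23-fold lower number from compound 1 to compound 3 (1.36 log units; beyond the scatter) in the same series. Among the compounds shown here, the step from hydrogen to piperidin-1-yl cannot be read, so compound 3 is the first compound here with a number instead of a limit: the limit of > 100000 nM in this assay, at which 2 of the 3 values shown sit.

Ring size and the added nitrogen change together, and the compounds shown do not separate them. 4-Methylpiperazin-1-yl on the same carbon would address the ring size, and 1,4-diazepan-1-yl would address the methyl.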